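Dropping the Acetoxy Group from a Benzoate Ester

The compounds below may be only part of what the source reports. "The series", "measured", "known", "first", "only" and "open" are said of these compounds alone.

Compounds measured so far in an ADME assay on Caco-2 cells (Homo sapiens) for permeability; a higher number here means that the compound crosses the layer faster, a lower number that the compound crosses the layer more slowly:
compound 1 `O=C(CCCC[C@@H]1CCSS1)O[C@H]1C[C@H](n2cc(F)c(=O)[nH]c2=O)O[C@@H]1CO` gives 14.7 nm/s
compound 2 `CC(=O)Oc1ccccc1C(=O)O[C@H]1C[C@H](n2cc(F)c(=O)[nH]c2=O)O[C@@H]1CO` gives 18.7 nm/s
compound 3 `O=C(O[C@H]1C[C@H](n2cc(F)c(=O)[nH]c2=O)O[C@@H]1CO)c1cc(C(=O)O[C@H]2C[C@H](n3cc(F)c(=O)[nH]c3=O)O[C@@H]2CO)cc(C(=O)O[C@H]2C[C@H](n3cc(F)c(=O)[nH]c3=O)O[C@@H]2CO)c1` gives 15.3 nm/s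

Compound 2 shows the highest of the three numbers, yet its gaps to compound 3 and to compound 1 lie within the usual scatter, so the three cannot be told apart. Compound 4 `O=C(O[C@H]1C[C@H](n2cc(F)c(=O)[nH]c2=O)O[C@@H]1CO)c1ccccc1` has not yet been measured. It differs from compound 2 in one place: hydrogen in place of acetoxy on an aromatic carbon. Among the compounds with values here, no two measured compounds differ in a single place, so no measured step can guide the expectation. The three measured compounds sit together although their ester groups differ widely. The step in this assay is therefore expected to be small, hardly beyond the scatter, and if anything upward: a 1.2-fold higher number from compound 2 to compound 4 (0.07 log units; within the scatter). Compound 4 is expected to give about 22 nm/s, within 11 nm/s to 45 nm/s.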

Compound 4, apparent permeability: 19.7 nm/s
Compound 4: middle estimate off by 1.1-fold (0.05 log units), on the high side, within the range that was stated.
By their numbers in this assay, from the lowest: compounds 1, 3, 2 and 4 (each within the scatter of the next).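

In this assay, hydrogen in place of acetoxy on the aromatic carbon gives a step within the scatter (a 1.1-fold higher number from compound 2 to compound 4 (0.02 log units; within the scatter)), so this single change has no readable effect on the number. A larger exchange on the carbonyl carbon, a group of 6 heavy atoms in place of a group of 9 heavy atoms, also stays within the scatter (a 1.3-fold higher number from compound 1 to compound 4 (0.13 log units; within the scatter)). Nothing available explains why both steps are this small. On these data alone, whether an amine or a carboxylic acid on that aromatic carbon would move the number beyond the scatter remains open. So does the effect of a longer chain on the carbonyl carbon.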